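The compounds below may be only part of what the source reports. "The series", "measured", "known", "first", "only" and "open" are said of these compounds alone.

Going by the values given here, compound 1 `COCC(C(=O)N1CCN(c2cccc(C(F)(F)F)c2)CC1)N1C(=O)CCC1=O` is one of two compounds so far followed in a functional assay on the whole organism (strain Swiss) with Mus musculus as the target, with a stated time of 0.25 h; on this read-out higher numbers stand for an effect only at larger amounts of compound and lower numbers for an effect already at smaller amounts. In this assay compound 1 gives 57.6 mg/kg, the lower of the two numbers, while compound 2 `CC(C(=O)N1CCN(c2ccccc2C(F)(F)F)CC1)N1C(=O)CCC1=O` gives 74.2 mg/kg; these two values lie within the usual scatter of each other, so nothing separates them. Compound 3 `CCC(C(=O)N1CCN(c2cccc(C(F)(F)F)c2)CC1)N1C(=O)CCC1=O` has not yet been measured. It differs from compound 1 in one place: methyl in place of methoxy on a saturated chain carbon, two bonds along the chain from an amide-type nitrogen in a ring and a carbonyl carbon, so the methoxymethyl side chain reads as ethyl. Among the compounds with values here, no pair of measured compounds shows the effect of such a change in this assay, and the two measured compounds differ from each other in more than one place, so no guide to the size of the step exists. The change is expected to give only a small step, a 1.0-fold lower number from compound 1 to compound 3 (0.02 log units; within the scatter), within the scatter and without a clear direction. Compound 3 is therefore estimated at 55 mg/kg, with a range from 25 mg/kg to 120 mg/kg.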

Compound 3, dose for half-maximal effect: 19.9 mg/kg
Beside the measured number, compound 3's estimate is 2.8-fold (0.44 log units) above it; measured number below the stated range.
By their numbers in this assay, from the lowest: compound 3; then compounds 1 and 2 (each within the scatter of the next).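

In this assay, methyl in place of methoxy on this saturated chain carbon gives a 2.9-fold lower number from compound 1 to compound 3 (0.46 log units; beyond the scatter), a modest step but one beyond the usual scatter. This shows that the side chain at this position affects the read-out, with the ethyl compound acting at smaller amounts than the methoxymethyl compound, even though the change swaps only two heavy atoms for one. No measurement at hand bears on what lies behind this step.

Still open, from the compounds shown here alone, is how the number would respond to other side chains here, such as a longer propyl chain, a hydroxymethyl group or an aminomethyl group. Also open, going by these compounds, is whether the same change would give a step of similar size on the core of compound 2, which differs from compound 1 in more than one place.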